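The compounds below may be only part of what the source reports. "The series", "measured", "known", "first", "only" and "open" are said of these compounds alone.

Measured so far in an assay on MCF7 cells for inhibition of Serine-protein kinase ATM (Homo sapiens), read by immunofluorescence, with a stated time of 1 h; a higher number here means a weaker inhibitor, a lower number a stronger inhibitor:
Compound 1 `COc1cc2ncnc(-n3nc(-c4ccc(Cl)cc4)nc3N)c2cc1OC` reaches only the assay limit, > 40000 nM.
Compound 2 `COc1cc2ncnc(-n3nc(-c4ccc(C)cc4)cc3N)c2cc1OC` likewise reaches only the assay limit, > 40000 nM.
Compound 3 `COc1cc2ncnc(-n3nc(-c4ccccn4)nc3N)c2cc1OCCCN1CC(C)OC(C)C1` gives 1600 nM.

Compound 3 is thus the only one of the three with a real number; the other two sit at the limit of > 40000 nM in this assay, at which 2 of the 3 values shown sit. Compound 4 `COc1cc2ncnc(-n3nc(-c4ccccn4)nc3N)c2cc1OCCCNC(=O)OCC(C)(C)C` differs from compound 3 in one place: (neopentyloxycarbonyl)amino in place of 2,6-dimethylmorpholin-4-yl on a saturated chain carbon, three bonds along the chain from an oxygen on an aromatic ring. Within the data shown here, no pair of measured compounds differs in just one place, so there is no measured step to lean on; the expectation rests on compound 3 alone. The change is expected to cost some potency in this assay, a step of a 1.6-fold higher number from compound 3 to compound 4 (0.19 log units; within the scatter) that may lie only a little beyond the usual scatter. For compound 4 the estimate in this assay is 2500 nM, within a range from 800 nM to 8000 nM.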

Compound 4, half-maximal inhibitory concentration: 1900 nM
Compound 4: middle estimate off by 1.3-fold (0.12 log units), on the high side, and the stated range covers the measured number.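

In this assay, putting (neopentyloxycarbonyl)amino in place of 2,6-dimethylmorpholin-4-yl on the saturated chain carbon gives a 1.2-fold higher number from compound 3 to compound 4 (0.07 log units; within the scatter) and so the two groups cannot be told apart here. At this place, then, a group with no ring and one hydrogen-bond donor reads the same as a ring group with no donor, so neither the ring nor the lack of a donor is needed for this level of potency.

From the compounds shown here alone, what a dimethylamino group, a carboxylic acid or a longer chain would give at this place stays open. Nothing shown explains why these two groups read alike.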